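The compounds below may be only part of what the source reports. "The series", "measured", "known", "first", "only" and "open" are said of these compounds alone.

Measured compounds:
Compound 1 `COc1cc2cc(Oc3ccc(NC(=O)Nc4ccc(C)cc4)cc3)c(C)nc2cc1OC` gives 107% in a functional assay on NCI/ADR-RES cells (Homo sapiens) for inhibition, read by sulforhodamine B assay, with a stated time of 48 h, tested at 10 uM; on this read-out lower numbers stand for a stronger effect and higher numbers for a weaker effect at the one concentration tested.
Compound 2 `COc1cc2cc(Oc3ccc(NC(=O)Nc4cccc(C(F)(F)F)c4)cc3)c(C)nc2cc1OC` gives 6.98% in this assay.

Of the two numbers, compound 2 stands lowest, and its nearest neighbour is compound 1, which differs from it only in the group attached to the amide-type nitrogen. That single exchange produced a number 100 percentage points lower from compound 1 to compound 2 (beyond the scatter), so the group on that nitrogen clearly governs the read-out in this pair.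

Compound 3 `COc1cc2cc(Oc3ccc(NC(=O)Nc4ccc(Cl)c(Cl)c4)cc3)c(C)nc2cc1OC` has not yet been measured. It differs from compound 2 by 3,4-dichlorophenyl in place of 3-(trifluoromethyl)phenyl on an amide-type nitrogen. Within the data shown here, no measured step involves a 3,4-dichlorophenyl group, so the only guidance is the large step from compound 1 to compound 2, which shows how strongly the choice of this group can move the number, but not in which direction a dichloro group would push it.

Compound 3 is therefore expected to stay close to compound 2, with a step of a number 8 percentage points higher from compound 2 to compound 3 (within the scatter) in this assay. The estimate for compound 3 is 15%, within a range from 3% to 45%.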

Compound 3, a percentage reported as activity, at one concentration (the size of the read-out at that concentration, not a potency): 17.1%
Estimate against measurement, compound 3: 2.1 percentage points below, and the stated range covers the measured number.
By their numbers in this assay, from the lowest: compound 2; then compound 3; then compound 1.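

In this assay the move to 3,4-dichlorophenyl on the amide-type nitrogen gives a number 89.9 percentage points lower from compound 1 to compound 3 (beyond the scatter) so the low number is not confined to the trifluoromethyl group: a ring carrying chlorine instead also lies far from the 4-methylphenyl of compound 1. Among these compounds, exchanging 3-(trifluoromethyl)phenyl for 3,4-dichlorophenyl gives only a number 10.1 percentage points higher from compound 2 to compound 3 (beyond the scatter) which shows that the two groups are not interchangeable, although this step is much smaller than the one from the 4-methylphenyl compound. Nothing available here explains why these groups give different numbers.

The three compounds do not separate the kind of group on the ring from where it sits, so a 4-(trifluoromethyl)phenyl or a 3-methylphenyl group would be informative. As far as these compounds go, it also stays open how a ring carrying a methoxy group, an amine or a carboxylic acid would behave at this nitrogen.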